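This account rests on a few compounds, and the source may have more. Where it says the series, first, only, none or still open, it means among the compounds named here.

Three compounds share one core and differ only in the group on the carbonyl carbon: compound 1 `NC(=O)N(O)CCC#Cc1ccc(OCCCCN2CCN(C(c3ccc(F)cc3)c3ccc(F)cc3)CC2)cc1`, compound 2 `CCOC(=O)N(O)CCC#Cc1ccc(OCCCCN2CCN(C(c3ccc(F)cc3)c3ccc(F)cc3)CC2)cc1` and compound 3 `COC(=O)N(O)CCC#Cc1ccc(OCCCCN2CCN(C(c3ccc(F)cc3)c3ccc(F)cc3)CC2)cc1`. In an assay on isolated protein for inhibition of Polyunsaturated fatty acid 5-lipoxygenase (Homo sapiens) (on this read-out lower numbers stand for stronger inhibition and higher numbers for weaker inhibition), compound 1 gives 193 nM, compound 2 gives 365 nM and compound 3 gives 170 nM, the lowest of the three numbers. The steps run a 1.9-fold higher number from compound 1 to compound 2 (0.28 log units; within the scatter), a 1.1-fold lower number from compound 1 to compound 3 (0.06 log units; within the scatter) and a 2.1-fold lower number from compound 2 to compound 3 (0.33 log units; beyond the scatter). Compound 4 `CC(C)COC(=O)N(O)CCC#Cc1ccc(OCCCCN2CCN(C(c3ccc(F)cc3)c3ccc(F)cc3)CC2)cc1` has not been measured; it differs from compound 3 by isopropyl in place of hydrogen on a saturated chain carbon bound to an oxygen next to a carbonyl group. Within the data shown here, only one measured step touches that carbon, a 2.1-fold lower number from compound 2 to compound 3 (0.33 log units; beyond the scatter), and it was modest; lengthening the chain again is expected to move the number the other way by a similar, modest amount, so the expected step is a 2.1-fold higher number from compound 3 to compound 4 (0.31 log units; beyond the scatter). Compound 4 is therefore estimated at 350 nM, within 150 nM to 850 nM.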

Compound 4, half-maximal inhibitory concentration: 420 nM
Beside the measured number, compound 4's estimate is 1.2-fold (0.08 log units) below it, within the range that was stated.
By their numbers in this assay, from the lowest: compounds 3, 1, 2 and 4 (each within the scatter of the next, the first and the last beyond it).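

In this assay isopropyl in place of hydrogen on the saturated chain carbon bound to an oxygen next to a carbonyl group gives a modest step (a 2.5-fold higher number from compound 3 to compound 4 (0.39 log units; beyond the scatter)), whereas isopropyl in place of methyl there stays within the scatter (a 1.2-fold higher number from compound 2 to compound 4 (0.06 log units; within the scatter)). Isobutoxy in place of amino on the carbonyl carbon gives a modest step (a 2.2-fold higher number from compound 1 to compound 4 (0.34 log units; beyond the scatter)), which ethoxy and methoxy did not. Nothing available explains these steps. As far as these compounds go, whether an unbranched butoxy group or a benzyloxy group would sit with compound 2 and compound 4 remains open.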